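Notes on the step from compound 2 to compound 3

This account rests on a few compounds, and the source may have more. Where it says the series, first, only, none or still open, it means among the compounds named here.

In an ADME assay on CHO cells (Cricetulus griseus) for cytotoxicity, read by MTT assay (on this read-out higher numbers stand for weaker inhibition and lower numbers for stronger inhibition), compound 2 (`CS(=O)(=O)Nc1cccc(-c2ccc3nccc(-c4ccncc4)c3n2)c1`) gives 13000 nM and sits within the scatter of compound 1 (`O=S(=O)(c1cccc(-c2ccc3nccc(-c4ccncc4)c3n2)c1)N1CCC(O)CC1`) at 8000 nM on this read-out. Compound 3 (`O=S(=O)(c1cccc(-c2ccc3nccc(-c4ccncc4)c3n2)c1)N1CC[C@H](O)C1`) carries (3-hydroxypyrrolidin-1-yl)sulfonyl in place of methanesulfonamido on an aromatic carbon. Within the data shown here, the one measured step bearing on this, methanesulfonamido in place of (4-hydroxypiperidin-1-yl)sulfonyl, is a 1.6-fold higher number from compound 1 to compound 2 (0.21 log units; within the scatter) and stays within the scatter. In this assay no step beyond the scatter is expected, and the estimated move is a 1.4-fold lower number from compound 2 to compound 3 (0.16 log units; within the scatter) only. Compound 3 is expected at 9000 nM with an estimated range from 4000 nM to 20000 nM in this series.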

Compound 3, half-maximal inhibitory concentration: 9000 nM
For compound 3 middle estimate and measured number coincide at the digits printed; low and high end bracket the measured number.
By their numbers in this assay, from the lowest: compounds 1, 3 and 2 (each within the scatter of the next).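

In this assay the ring on the sulfonyl sulfur gets its first comparison, a 1.1-fold higher number from compound 1 to compound 3 (0.05 log units; within the scatter) and so 3-hydroxypyrrolidin-1-yl and 4-hydroxypiperidin-1-yl are not told apart at this position. The five-membered ring also gives no separation from methanesulfonamido on the aromatic carbon, with a 1.4-fold lower number from compound 2 to compound 3 (0.16 log units; within the scatter) as the step. No measured evidence accounts for these readings. Open, as far as these compounds go, is whether a piperazine or a carboxylic acid on the sulfonyl group would move the number beyond the scatter. Also open, from the compounds shown here alone, is whether the opposite stereocentre of 3-hydroxypyrrolidin-1-yl would read any differently.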